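A few compounds are considered here, and "the series" means these few. Any claim that something is new, unique, unknown or untested is made for them only; others in the source may bear on it.

In the series at hand, compound 1 `COc1ccc(-c2c(Nc3ccc(F)cc3)c3ccccc3oc2=O)cc1` carries a 4-fluorophenyl group on the nitrogen of its core. Tested in a functional assay on HCT-116 cells (Homo sapiens) for antiproliferative activity, read by MTT assay, with a stated time of 48 h (on this read-out lower numbers stand for stronger inhibition and higher numbers for weaker inhibition), compound 1 gives 39400 nM. Its partner compound 2 `COc1ccc(-c2c(Nc3ccc(C)c(O)c3)c3ccccc3oc2=O)cc1` differs in one place only, (3-hydroxy-4-methylphenyl in place of 4-fluorophenyl on a nitrogen on an aromatic ring), and in this assay compound 2 gives 12300 nM. The resulting step, a 3.2-fold lower number from compound 1 to compound 2 (0.51 log units; beyond the scatter), counts as a modest gain in inhibition.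

Compound 3 `COc1ccc2oc(=O)c(C(=O)C(F)(F)F)c(Nc3ccc(F)cc3)c2c1` belongs to a second core that bears a trifluoroacetyl group and a methoxy group at another position of the ring system; the difference between the two cores is not broken down here. In this assay compound 3 gives "not determined" (no result reported), so no number stands behind it.

Compound 4 `COc1ccc2oc(=O)c(C(=O)C(F)(F)F)c(Nc3ccc(C)c(O)c3)c2c1` repeats the same kind of change on this second core, (3-hydroxy-4-methylphenyl in place of 4-fluorophenyl on a nitrogen on an aromatic ring). The place is described in identical words for both pairs, so the change is the same one in the same surroundings, but with nothing measured for compound 3 there is no anchor from which a step could be read. Any expectation for compound 4 therefore rests on compound 2, whose value of 12300 nM shows what the 3-hydroxy-4-methylphenyl group reached on the first core, together with an unknown shift from the change of core. On that basis compound 4 is expected to land near 10000 nM in this assay, with a wide spread from 2000 nM to 50000 nM.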

Compound 4, half-maximal inhibitory concentration: 4620 nM
Beside the measured number, compound 4's estimate is 2.2-fold (0.34 log units) above it; the measured number falls inside the stated range.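

For the compounds shown here, with no number for compound 3 in this assay, no step from compound 3 to compound 4 can be read, and compound 4 stands alone at 4620 nM. The compounds shown leave open whether the change from 4-fluorophenyl to 3-hydroxy-4-methylphenyl does on this core what it does on the core of compound 1. Nothing at hand offers an explanation for the value of compound 4.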